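Ethoxy in Place of Propylsulfanyl on a Shared Core

The compounds below may be only part of what the source reports. "The series", "measured", "known", "first", "only" and "open" are said of these compounds alone.

Three measured compounds share one core and differ only in the group on a single aromatic carbon. In a functional assay on the whole organism for activation, with Mus musculus as the target (a lower number here means that less compound is needed, a higher number that more compound is needed for the effect), compound 1 `CCc1nc(N)c2nc(O)n(Cc3ccccc3)c2n1` gives 3 mg/kg. Compound 2 `CCCCc1nc(N)c2nc(O)n(Cc3ccccc3)c2n1` gives 0.3 mg/kg, and compound 3 `CCCSc1nc(N)c2nc(O)n(Cc3ccccc3)c2n1` gives 0.1 mg/kg, the lowest of the three numbers. The steps of a 10-fold lower number from compound 1 to compound 2 (1.00 log units; beyond the scatter) and a 30-fold lower number from compound 1 to compound 3 (1.48 log units; beyond the scatter) both ran toward lower numbers, as did a 3.0-fold lower number from compound 2 to compound 3 (0.48 log units; beyond the scatter). Compound 4 `CCOc1nc(N)c2nc(O)n(Cc3ccccc3)c2n1` carries ethoxy in place of propylsulfanyl on an aromatic carbon, a group with fewer heavy atoms and no sulfur. Because a 10-fold lower number from compound 1 to compound 2 (1.00 log units; beyond the scatter) and a 30-fold lower number from compound 1 to compound 3 (1.48 log units; beyond the scatter) favoured the longer groups, the ethoxy is expected to give a higher number than compound 3. The expected step is therefore a 10-fold higher number from compound 3 to compound 4 (1.00 log units; beyond the scatter). Compound 4 is estimated at 1 mg/kg, most likely between 0.3 mg/kg and 3 mg/kg.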

Compound 4, minimum effective dose: 0.3 mg/kg
The estimate for compound 4 lay 3.3-fold (0.52 log units) above the measured number, within the range that was stated.
By their numbers in this assay, from the lowest: compound 3; then compounds 2 and 4 (each within the scatter of the next); then compound 1.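

At this aromatic carbon, ethoxy in place of propylsulfanyl gives a 3.0-fold higher number from compound 3 to compound 4 (0.48 log units; beyond the scatter) in this assay, so the sulfur-linked chain keeps its lead. Ethoxy in place of butyl gives no change at the digits printed from compound 2 to compound 4 (within the scatter) and thus matches the longer carbon chain. Ethoxy in place of ethyl gives a 10-fold lower number from compound 1 to compound 4 (1.00 log units; beyond the scatter) and this oxygen-linked change is as large as a 10-fold lower number from compound 1 to compound 2 (1.00 log units; beyond the scatter) in the same assay. Going by these compounds, whether a longer oxygen-linked chain such as butoxy, or an amine at this carbon, would go lower remains open. Nothing available explains why these groups differ.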